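Removing tert-butoxycarbonyl from compound 2

A few compounds are considered here, and "the series" means these few. Any claim that something is new, unique, unknown or untested is made for them only; others in the source may bear on it.

Compound 1 `CCn1c(C(=O)NCC(=O)OC)ccc1C(CC)(CC)c1ccc(OCS(=O)(=O)c2ccccc2)c(C)c1` gives 20000 nM
Compound 2 `CCn1c(C(=O)NCCNC(=O)OC(C)(C)C)ccc1C(CC)(CC)c1ccc(OCS(=O)(=O)c2ccccc2)c(C)c1` gives > 50000 nM
Compound 3 `CCn1c(C(=O)NCCN)ccc1C(CC)(CC)c1ccc(OCS(=O)(=O)c2ccccc2)c(C)c1` is not yet measured

These values come from a functional assay on BXPC-3 cells (Homo sapiens) for antiproliferative activity, read by MTT assay, with a stated time of 24 h; a higher number here means a weaker inhibitor, a lower number a stronger inhibitor. For compound 2 the entry > 50000 nM is a limit of the assay and not a number. Compound 3 carries hydrogen in place of tert-butoxycarbonyl on an amine nitrogen. Within the data shown here, only one measured step bears on this change: an at least 2.5-fold higher number from compound 1 to compound 2 (0.39 log units; beyond the scatter). That step brought in the same tert-butoxycarbonyl group, as part of ((tert-butoxycarbonyl)amino)methyl, and its size is known only as a bound. Removing the group is therefore expected to give a modest move towards a lower number in this assay, roughly back to the level of compound 1 at 20000 nM. The expected change is an estimated at least 3.3-fold lower number from compound 2 to compound 3 (0.52 log units; beyond the scatter). Compound 3 is estimated at 15000 nM, with an expected range of 4000 nM to 50000 nM.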

Compound 3, half-maximal inhibitory concentration: 6430 nM
Compound 3: middle estimate off by 2.3-fold (0.37 log units), on the high side; the measured number falls inside the stated range.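

In this assay, hydrogen in place of tert-butoxycarbonyl on an amine nitrogen gives an at least 7.7-fold lower number from compound 2 to compound 3 (0.89 log units; beyond the scatter), a size known only as a bound, as compound 2 stands at a limit of the assay and not at a number: the limit of > 50000 nM in this assay, at which 1 of the 3 values shown sits. The free amine does more than return to the level of the methyl ester: aminomethyl in place of methoxycarbonyl gives a 3.1-fold lower number from compound 1 to compound 3 (0.49 log units; beyond the scatter), so the end of this chain can move the number in both directions. Of these three compounds, the one carrying 2-aminoethyl has the lowest number, with its steps to the other two beyond the scatter.

As far as these compounds go, it remains open whether the amine itself or the chain length matters, which a longer chain ending in an amine, or a carboxylic acid in place of the ester, could help to separate. Compound 3 at 6430 nM is still a weak inhibitor, and what lies behind its gain is not shown.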